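A few compounds are considered here, and "the series" means these few. Any claim that something is new, unique, unknown or untested is made for them only; others in the source may bear on it.

Compound 1 `COc1ccc2c(=O)cc(/C=C/c3ccc(OC(F)(F)F)cc3)oc2c1` in a functional assay on PC-3 cells (Homo sapiens) for antiproliferative activity, read by MTT assay, with a stated time of 12 h (on this read-out lower numbers stand for stronger inhibition and higher numbers for weaker inhibition), gives > 40000 nM.
Compound 2 `COc1ccc2c(=O)cc(/C=C/c3ccc(OC(F)(F)F)cc3)oc2c1OC` in this assay gives > 40000 nM.

Both of these values are limits of the assay, not numbers, as the limit of > 40000 nM in this assay, at which 2 of the 2 values shown sit, notes. The step from compound 1 to compound 2, a methoxy in place of hydrogen on an aromatic carbon, is therefore a step that the two limits leave unreadable from compound 1 to compound 2. Compound 1 itself stands only at a limit. Compound 3 `O=c1cc(/C=C/c2ccc(OC(F)(F)F)cc2)oc2ccccc12` differs from compound 1 by hydrogen in place of methoxy on an aromatic carbon. Among the measured compounds shown here, no measured step reads in size, so no resolved shift is expected, and compound 3 is expected to remain near the limit, with an estimated step that the limit leaves unreadable from compound 1 to compound 3. The estimate for compound 3 is 50000 nM, ranging from 15000 nM to 200000 nM.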

Compound 3, half-maximal inhibitory concentration: 28900 nM
Beside the measured number, compound 3's estimate is 1.7-fold (0.24 log units) above it, within the range that was stated.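

Of the three compounds, compound 3 alone gives a number rather than a limit in this assay, so this position now yields a step with a readable floor. Hydrogen in place of methoxy gives an at least 1.3-fold lower number from compound 1 to compound 3 (0.14 log units; that floor lies within the scatter). That step is bounded on one side only, because compound 1 stands at a limit: the limit of > 40000 nM in this assay, at which 2 of the 3 values shown sit.

On these data alone, how far the true step exceeds that floor stays open. So does what a hydroxyl, an amine or a longer alkoxy chain on this aromatic carbon would give in this assay.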